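The compounds below may be only part of what the source reports. "The series", "measured", "known", "first", "only" and "open" are said of these compounds alone.

Measured so far in a physicochemical assay for solubility, in phosphate buffer, with a stated time of 16 h; on this read-out lower numbers stand for lower solubility and higher numbers for higher solubility:
compound 1 `CC(=O)OC[C@H]1O[C@@H](n2cnc3c(N)ncnc32)[C@@H](O)[C@@H]1O`: 6600 ug/mL
compound 2 `Nc1ncnc2c1ncn2[C@@H]1O[C@H](COC(=O)CCc2ccccc2)[C@@H](O)[C@@H]1O`: 1500 ug/mL
compound 3 `CCCCCC(=O)OC[C@H]1O[C@@H](n2cnc3c(N)ncnc32)[C@@H](O)[C@@H]1O`: 2500 ug/mL

Compound 2 stands at the low end of these numbers: a 1.7-fold higher number from compound 2 to compound 3 (0.22 log units; within the scatter), whereas a 4.4-fold lower number from compound 1 to compound 2 (0.64 log units; beyond the scatter). Compound 4 `Nc1ncnc2c1ncn2[C@@H]1O[C@H](COC(=O)c2ccccc2)[C@@H](O)[C@@H]1O` differs from compound 2 by phenyl in place of phenethyl on a carbonyl carbon. Among the compounds with values here, the steps that bear on this are the additions of carbon to the acyl group, a 4.4-fold lower number from compound 1 to compound 2 (0.64 log units; beyond the scatter) and a 2.6-fold lower number from compound 1 to compound 3 (0.42 log units; beyond the scatter), both modest drops, while a 1.7-fold higher number from compound 2 to compound 3 (0.22 log units; within the scatter). Compound 4 carries fewer acyl carbons than compound 2 yet more than compound 1, so a modest rise is expected for compound 4, a 1.5-fold higher number from compound 2 to compound 4 (0.17 log units; within the scatter), staying below compound 1. Compound 4 is therefore estimated at 2200 ug/mL, within 900 ug/mL to 5000 ug/mL.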

Compound 4, solubility: 80 ug/mL
Beside the measured number, compound 4's estimate is 28-fold (1.44 log units) above it; the whole stated range lies above it.
By their numbers in this assay, from the lowest: compound 4; then compounds 2 and 3 (each within the scatter of the next); then compound 1.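

In this assay phenyl in place of phenethyl on a carbonyl carbon gives a 19-fold lower number from compound 2 to compound 4 (1.27 log units; beyond the scatter) even though both groups hold one six-membered aromatic ring of carbon only. Against the other two esters, phenyl gives a 31-fold lower number from compound 3 to compound 4 (1.49 log units; beyond the scatter) and an 83-fold lower number from compound 1 to compound 4 (1.92 log units; beyond the scatter) so the count of carbons in the group on this carbonyl carbon does not order the four numbers, with compound 4 going against the order that compounds 1, 2 and 3 suggested. Nothing measured here bears on the reason for these drops. From the compounds shown here alone, whether a benzyl group on the carbonyl carbon would sit with compound 2 or with compound 4 stays open, as does the effect of an amine on the phenyl ring.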